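This account rests on a few compounds, and the source may have more. Where it says the series, first, only, none or still open, it means among the compounds named here.

Compound 1 `Oc1ccccc1-c1cc(-c2cccs2)cc(-c2ccccc2O)n1` carries two 2-hydroxyphenyl groups on its core. In a functional assay on T47D cells (Homo sapiens) for cytotoxicity, read by CCK-8 assay (on this read-out lower numbers stand for stronger inhibition and higher numbers for weaker inhibition), compound 1 reaches only a limit, > 50000 nM. Compound 2 `Oc1cccc(-c2cc(-c3cccs3)cc(-c3ccccc3O)n2)c1` differs from it by 3-hydroxyphenyl in place of 2-hydroxyphenyl on an aromatic carbon. In this assay compound 2 also stops at a limit, > 50000 nM. The step that the two limits leave unreadable from compound 1 to compound 2 therefore cannot be sized, because of the limit of > 50000 nM in this assay, at which 3 of the 3 values shown sit. Compound 3 `Oc1cccc(-c2cc(-c3ccoc3)cc(-c3ccccc3O)n2)c1` has a core whose difference from that of compound 1 is not broken down here. In this assay compound 3 again gives only a limit, > 50000 nM. Compound 4 `Oc1cccc(-c2cc(-c3ccoc3)cc(-c3cccc(O)c3)n2)c1` differs from compound 3 by 3-hydroxyphenyl in place of 2-hydroxyphenyl on an aromatic carbon, the same kind of change, though here the place is meta to a 3-hydroxyphenyl group and meta to a furan-3-yl group rather than meta to a 2-hydroxyphenyl group and a thiophen-2-yl group. Resting on a step that the two limits leave unreadable from compound 1 to compound 2 and on (the limit of > 50000 nM in this assay, at which 3 of the 3 values shown sit), the step that the limit leaves unreadable from compound 3 to compound 4 is expected to stay unreadable. Compound 4 is expected to give around 80000 nM in this assay, most likely as a limit again.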

Compound 4, half-maximal inhibitory concentration: 2590 nM
Estimate against measurement, compound 4: 31-fold (1.49 log units) above, and the stated range ends above it.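

In this assay, with a furan-3-yl group and a 3-hydroxyphenyl group already on the core, putting 3-hydroxyphenyl in place of 2-hydroxyphenyl gives an at least 19-fold lower number from compound 3 to compound 4 (1.28 log units; beyond the scatter), a large step that lies beyond the scatter. The same kind of change on the core of compound 1, which carries thiophen-2-yl and a second 2-hydroxyphenyl group, cannot be read, because the values of compound 1 and compound 2 are both limits: the limit of > 50000 nM in this assay, at which 3 of the 4 values shown sit. The series therefore shows the change working on one core, but it does not show whether the change carries over to another.

As far as these compounds go, it remains open whether thiophen-2-yl with two 3-hydroxyphenyl groups would match compound 4. From the compounds shown here alone, it also remains open whether an amine or a carboxylic acid could stand in for either hydroxyl group.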